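A few compounds are considered here, and "the series" means these few. Any claim that something is new, unique, unknown or untested is made for them only; others in the source may bear on it.

Working notes on the series, read in a toxicity assay on NIH3T3 cells (Mus musculus) for cytotoxicity, read by resazurin assay; on this read-out higher numbers stand for an effect only at larger amounts of compound and lower numbers for an effect already at smaller amounts. For the measured compounds named here, compound 1 (`c1ccc(-c2ccc(Cn3cncc3CNc3cccc(-c4ccccc4)c3)cc2)cc1`) gives 10000 nM, the only actual number so far. Compound 2 (`Cc1cccc(-c2cccc(NCc3cncn3Cc3ccccc3)c2)c1C`) gives > 1000 nM, which is a limit and not a number. Compound 3 (`COC(=O)c1ccc(NCc2cncn2Cc2ccc([N+](=O)[O-])cc2)cc1-c1ccccc1`) gives > 10000 nM, which is also a limit. Going by the values given here, the series offers no measured comparison of compounds differing in one place. Compound 4 (`c1ccc(-c2ccc(Cn3cncc3CNc3ccc(-c4nc5ccccc5s4)c(-c4ccccc4)c3)cc2)cc1`) has 1,3-benzothiazol-2-yl in place of hydrogen on an aromatic carbon of compound 1, ortho to a phenyl group (1,3-benzothiazol-2-yl in place of hydrogen on an aromatic carbon). Among the compounds with values here, with no measured step to draw on, no shift beyond the usual scatter is expected, and the expected change is no change at the digits printed from compound 1 to compound 4 (within the scatter). For compound 4 the estimated value is 10000 nM, with an expected range of 3000 nM to 30000 nM.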

Compound 4, half-maximal effective concentration: > 1000 nM
Compound 4: a limit, no number; the forecaster's own chance of this, stated with the estimate: 45%; the middle value is on the limit's open side.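

For the compounds shown here, compound 4 gives > 1000 nM, which is a limit and not a number, so no step from compound 1 to compound 4 can be read. The compounds shown leave open whether 1,3-benzothiazol-2-yl in place of hydrogen on an aromatic carbon shifts the value of compound 1 at all.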